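Dropping the Chloro Group of Compound 3

The source may report more compounds than this note shows. Statements on the series, on what has been measured and on what is new or still open speak of the compounds shown alone.

Compound 1 `Cn1cc(C2=C(c3n[nH]c4ncccc34)C(=O)NC2=O)c2ccccc21`: > 100000 nM (a limit of the assay)
Compound 2 `Cn1cc(C2=C(c3nn(CCn4ccnc4)c4ncccc34)C(=O)NC2=O)c2ccccc21`: > 100000 nM (a limit of the assay)
Compound 3 `Cn1cc(C2=C(c3nn(CCCN4CCCCC4)c4ncccc34)C(=O)N(c3ccc(Cl)cc3)C2=O)c2ccccc21`: 28700 nM

In a functional assay on A549 cells (Homo sapiens) for antiproliferative activity, read by MTT assay, with a stated time of 48 h (a lower number here means a stronger inhibitor, a higher number a weaker inhibitor), compound 1 reaches only a limit of the assay. Compound 2 also reaches only a limit. The step that the two limits leave unreadable from compound 1 to compound 2 is therefore unreadable, as both values sit at the limit of > 100000 nM in this assay, at which 2 of the 3 values shown sit. Compound 3 alone gives a number, and it is a weak one.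

Compound 4 `Cn1cc(C2=C(c3nn(CCCN4CCCCC4)c4ncccc34)C(=O)N(c3ccccc3)C2=O)c2ccccc21` differs from compound 3 by hydrogen in place of chloro on an aromatic carbon. Going by the values given here, no measured step touches this position, so the only guide is the value of compound 3 itself. The expected step of a 1.2-fold higher number from compound 3 to compound 4 (0.09 log units; within the scatter) is small, within the usual scatter, and compound 4 is estimated at 35000 nM, between 12000 nM and 100000 nM in this assay.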

Compound 4, half-maximal inhibitory concentration: 20600 nM
Beside the measured number, compound 4's estimate is 1.7-fold (0.23 log units) above it; low and high end bracket the measured number.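

In this assay, replacing the chloro group with hydrogen gives a 1.4-fold lower number from compound 3 to compound 4 (0.14 log units; within the scatter) and so leaves compound 3 and compound 4 indistinguishable. This first readable step at this position, on an aromatic carbon para to a large group, shows that the weak activity seen here does not depend on the chloro group. Nothing measured here gives a reason for this result.

Still open, on these data alone, is whether a different group at this position, such as methoxy, an amine or a carboxylic acid, would produce a step beyond the scatter. Also open, as far as these compounds go, is whether the change from 4-chlorophenyl to phenyl would read the same way in more active compounds.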